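Removing the Amide from an Indole-Bearing Kinase Core

The compounds below may be only part of what the source reports. "The series", "measured", "known", "first", "only" and "open" are said of these compounds alone.

Measured so far:
compound 1, `CC[C@@H]1C(=O)N(C)c2cnc(-n3ccc4cc(C(=O)NC(C)C)ccc43)nc2N1C1CCCC1`: 292 nM
compound 2, `CC[C@@H]1C(=O)N(C)c2cnc(Nc3ccc(S(=O)(=O)NCCCO)cc3)nc2N1C1CCCC1`: 357 nM

Both compounds share one core and were tested in a functional assay on HeLa cells (Homo sapiens) for antiproliferative activity, read by CCK-8 assay, with a stated time of 72 h; on this read-out higher numbers stand for weaker inhibition of growth and lower numbers for stronger inhibition of growth. Compound 1 gives 292 nM, and compound 2 gives 357 nM; these two numbers lie within the usual scatter of each other, so neither can be called the stronger. Compound 3 `CC[C@@H]1C(=O)N(C)c2cnc(-n3ccc4ccccc43)nc2N1C1CCCC1` differs from compound 1 in a single place: hydrogen in place of isopropylcarbamoyl on an aromatic carbon. Within the data shown here, no measured pair shows this kind of change, so the expectation rests on the structural change alone. A modest shift toward weaker growth inhibition is expected, estimated as a 2.4-fold higher number from compound 1 to compound 3 (0.38 log units; beyond the scatter). Compound 3 is therefore expected to give about 700 nM, within a range from 250 nM to 2000 nM.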

Compound 3, concentration for 50% growth inhibition: 33900 nM
Compound 3: middle estimate off by 48-fold (1.69 log units), on the low side; measured number outside the range, above it.
By their numbers in this assay, from the lowest: compounds 1 and 2 (each within the scatter of the next); then compound 3.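

Measured in this assay the change from isopropylcarbamoyl to hydrogen on this aromatic carbon gives a 120-fold higher number from compound 1 to compound 3 (2.06 log units; beyond the scatter) and shows that growth inhibition by this series depends strongly on what this carbon carries, with hydrogen alone retaining little of it. The earlier compounds shown here held no pair that isolated this position. Nothing measured here explains the loss.

From the compounds shown here alone, it remains open whether the isopropyl part matters or the carbonyl and its nitrogen suffice, and whether a primary amide, a carboxylic acid or an amine at this carbon would restore growth inhibition.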